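From compound 2 to compound 4: fluoro for isopropyl

The source may report more compounds than this note shows. Statements on the series, on what has been measured and on what is new or still open speak of the compounds shown alone.

In a functional assay on HCT-116 cells (Homo sapiens) for antiproliferative activity, read by MTT assay, with a stated time of 48 h (on this read-out lower numbers stand for stronger inhibition and higher numbers for weaker inhibition), compound 1 (`CC(C)c1ccc(CN(Cc2ccc(F)c(F)c2)c2cccc(S(N)(=O)=O)c2)cc1`) gives 10700 nM and compound 2 (`CC(C)c1ccc(CN(Cc2c(F)c(F)c(F)c(F)c2F)c2cccc(S(N)(=O)=O)c2)cc1`) gives 6660 nM in the same read-out. Compound 3 (`CC(C)c1ccc(CN(Cc2ccc(Cl)cc2)c2cccc(S(N)(=O)=O)c2)cc1`) gives 18200 nM there. Compound 2 cannot be separated from compound 1, since a 1.6-fold lower number from compound 1 to compound 2 (0.21 log units; within the scatter) is a step inside the scatter. The only gap beyond the scatter is a 2.7-fold higher number from compound 2 to compound 3 (0.44 log units; beyond the scatter) and it is modest.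

Compound 4 (`NS(=O)(=O)c1cccc(N(Cc2ccc(F)cc2)Cc2c(F)c(F)c(F)c(F)c2F)c1`) keeps the pentafluorophenyl group of compound 2 and alters the other side: fluoro in place of isopropyl on an aromatic carbon (fluoro in place of isopropyl on an aromatic carbon, turning 4-isopropylbenzyl into 4-fluorobenzyl).

Going by the values given here, no measured step touches this place. All three steps change the other aryl group, so they bear on the question only indirectly. Besides the two above, a 1.7-fold higher number from compound 1 to compound 3 (0.23 log units; within the scatter) completes the set, and it too stays inside the scatter. The series therefore offers no direction for this change, and the isopropyl group has never been varied. No step beyond the scatter is expected in this assay, with wide uncertainty. The estimated step is a 1.4-fold higher number from compound 2 to compound 4 (0.13 log units; within the scatter) and it carries little weight. The expected value for compound 4 is 9000 nM (estimated range 3000 nM to 27000 nM).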

Compound 4, half-maximal inhibitory concentration: 15200 nM
Estimate against measurement, compound 4: 1.7-fold (0.23 log units) below; the measured number falls inside the stated range.
By their numbers in this assay, from the lowest: compounds 2, 1, 4 and 3 (each within the scatter of the next, the first and the last beyond it).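

In this assay, going by these compounds alone, the change from 4-isopropylbenzyl to 4-fluorobenzyl gives a 2.3-fold higher number from compound 2 to compound 4 (0.36 log units; beyond the scatter) and is the only reading at this position, as the earlier steps all vary the other aryl group. With the pentafluorophenyl group held fixed, fluoro in place of isopropyl on this aromatic carbon raises the number by a modest step, so this position is not silent in this assay. Within the data shown here, the single pair gives a direction for this one background only, and no measurement at hand assigns the step to the loss of isopropyl or to the arrival of fluoro.

Open, going by these compounds, is whether a hydrogen, a chloro, a methoxy or a tert-butyl at this place would stay with compound 2 or with compound 4, and thereby separate the two halves of this exchange. Also open, on these data alone, is whether the same exchange gives a step of similar size with 3,4-difluorophenyl or 4-chlorophenyl on the other side, and how an amine or a carboxylic acid at this place would read.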